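The source may report more compounds than this note shows. Statements on the series, on what has been measured and on what is new or still open speak of the compounds shown alone.

Measured compounds:
- compound 1 `CC(C)N(O)C(=O)NCCSc1nc2ccccc2s1`: 130 nM
- compound 2 `CCOc1ccc2nc(SCCNC(=O)N(O)C(C)C)sc2c1`: 390 nM
- compound 3 `O=C(NO)NCCSc1nc2ccccc2s1`: 5200 nM

These three compounds share a core in which a hydroxyurea is joined through a short chain to a sulfur-linked fused ring system. In a functional assay for inhibition of Polyunsaturated fatty acid 5-lipoxygenase (Homo sapiens) (a lower number here means that less compound is needed, a higher number that more compound is needed for the effect), compound 1 gives 130 nM, the lowest number among the three. The other two compounds sit above it: the step of a 3.0-fold higher number from compound 1 to compound 2 (0.48 log units; beyond the scatter) is modest, while the step of a 40-fold higher number from compound 1 to compound 3 (1.60 log units; beyond the scatter) is large. So among these compounds, stripping the isopropyl from the hydroxylated nitrogen costs far more than decorating the fused ring.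

Compound 4 `CC(C)N(O)C(=O)NCCSc1nc2cc(Cl)ccc2s1` differs from compound 1 only on the ring: chloro in place of hydrogen on an aromatic carbon. Among the measured compounds shown here, the one measured step that bears on a ring substitution is a 3.0-fold higher number from compound 1 to compound 2 (0.48 log units; beyond the scatter), a modest increase in the number, though it involves a different group at a different place on the ring. For the measured compounds named here, no other step speaks to this change. The expectation for compound 4 is therefore a small step, if any, most likely a slight rise in the number, a 1.5-fold higher number from compound 1 to compound 4 (0.19 log units; within the scatter). Compound 4 is estimated at 200 nM, with a range from 70 nM to 600 nM in this assay.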

Compound 4, half-maximal effective concentration: 70 nM
Estimate against measurement, compound 4: 2.9-fold (0.46 log units) above; the measured number falls inside the stated range.
By their numbers in this assay, from the lowest: compounds 4 and 1 (each within the scatter of the next); then compound 2; then compound 3.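

In this assay, chloro on this aromatic carbon, meta to a fused ring and para to a fused ring, gives a 1.9-fold lower number from compound 1 to compound 4 (0.27 log units; within the scatter), so this single added atom leaves the number within the usual scatter. Among the compounds shown here, until now the only ring change on record was a 3.0-fold higher number from compound 1 to compound 2 (0.48 log units; beyond the scatter), and that step alone could suggest that any added ring group raises the number; this new step shows that a ring substituent need not do so. Because ethoxy and chloro differ in both identity and place on the ring, these two steps cannot separate the effect of the group from the effect of its position, and no measurement at hand explains either result.

On these data alone, it remains open whether a different group at this same carbon, such as methyl, methoxy, an amine or a carboxylic acid, would also stay within the scatter of compound 1, and whether chloro would give a similar result at the carbon that carries ethoxy in compound 2. Also unknown is whether the large cost of removing isopropyl would carry over to a compound that has chloro on the ring.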